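The source may report more compounds than this note shows. Statements on the series, on what has been measured and on what is new or still open speak of the compounds shown alone.

Compound 1 `COc1ccccc1/C=c1/[nH]c(=O)/c(=C\c2ccccc2OC)n(C)c1=O` is the reference point here: in a functional assay on NCI-H1975 cells (Homo sapiens) for cytotoxicity, read by CCK-8 assay, with a stated time of 72 h (a higher number here means a weaker inhibitor, a lower number a stronger inhibitor), compound 1 gives 16900 nM. Compound 2 `C=CCn1c(=O)/c(=C\c2cc(Br)ccc2F)[nH]c(=O)/c1=C\c1ccccc1OC` stands without a single number in this assay, where compound 2 is reported as "not active" (no number reported), so its position can only be placed at the weak end. Compound 3 `C=CCn1c(=O)/c(=C\c2cc(F)ccc2C)[nH]c(=O)/c1=C\c1ccccc1OC` carries 5-fluoro-2-methylphenyl in place of 5-bromo-2-fluorophenyl on a double-bonded chain carbon bound to an aromatic carbon. Going by the values given here, with no measured step to lean on, the change from compound 2 to compound 3 is expected to move this assay little, if at all beyond the scatter, toward weak activity. Compound 3 is therefore estimated at 30000 nM, within 8000 nM to 100000 nM.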

Compound 3, half-maximal inhibitory concentration: 7300 nM
Compound 3: the middle estimate sits 4.1-fold (0.61 log units) above what was measured, and the stated range ends above it.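

Going by these compounds alone, compound 2 carries no number, so no step to compound 3 can be read. The compounds shown leave open how much the change from 5-bromo-2-fluorophenyl to 5-fluoro-2-methylphenyl itself contributes, and no supporting evidence bears on this.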